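The source may report more compounds than this note shows. Statements on the series, on what has been measured and on what is new or still open speak of the compounds shown alone.

The series examined here consists of four compounds built on a shared core, three of which have been measured in a functional assay, with a stated time of 30 min; on this read-out lower numbers stand for stronger inhibition and higher numbers for weaker inhibition. Compound 1, with the structure `COc1ccc(/C=N/c2ccc(OCc3ccccc3)cc2)c(O)c1`, is the reference point for the step that follows. In this assay compound 1 returns only a limit, > 200000 nM, and not a number. Compound 2, with the structure `Oc1ccc2ccccc2c1/C=N/c1ccc(OCc2ccccc2)cc1`, likewise returns only a limit in this assay, > 200000 nM. Compound 3, with the structure `COc1cccc(/C=N/c2ccc(OCc3ccccc3)cc2)c1O`, also returns only a limit in this assay, > 200000 nM. The position of compound 1 is therefore set by the limit of > 200000 nM in this assay, at which 3 of the 3 values shown sit, so that nothing separates it from compound 2 or compound 3 on the numbers shown.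

Compound 4, with the structure `Oc1ccc(/C=N/c2ccc(OCc3ccccc3)cc2)c(O)c1`, has not yet been measured in this assay. Its difference from compound 1 is hydrogen in place of methyl on an oxygen on an aromatic ring. Going by the values given here, since every measured value in the set is a limit, no step between measured compounds is available, and the hydrogen in place of methyl is expected to produce no step beyond the scatter of this assay. The step expected is a step that the limit leaves unreadable from compound 1 to compound 4. Compound 4 is accordingly expected to give 300000 nM, with a range from 100000 nM to 1000000 nM, most likely again as a limit.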

Compound 4, half-maximal inhibitory concentration: > 200000 nM
Compound 4: only a limit was reported; the forecaster's own chance of this, stated with the estimate: 85%; the middle value is on the limit's open side.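

In this assay compound 4 gives > 200000 nM, which is a limit and not a number. The step between compound 1 and compound 4, methoxy to hydroxy, cannot be read, because both carry only limits: the limit of > 200000 nM in this assay, at which 4 of the 4 values shown sit. The compounds shown leave open how strongly any of them inhibits in this assay, and whether methoxy to hydroxy changes that at all.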